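Weighing a two-heteroatom ring against a pyridinone core

A few compounds are considered here, and "the series" means these few. Any claim that something is new, unique, unknown or untested is made for them only; others in the source may bear on it.

Among the measured compounds shown here, compound 1, `CC(C)Oc1cc(Oc2ccc(S(C)(=O)=O)cc2)cc(-c2cccc(=O)[nH]2)c1`, gives 2.82 in a physicochemical assay for lipophilicity, using the shake flask method (on this read-out lower numbers stand for lower lipophilicity and higher numbers for higher lipophilicity), and is the higher of the two numbers known, while compound 2, `CC(C)Oc1cc(Oc2ccc(S(C)(=O)=O)cc2)cc(-c2cncc(=O)[nH]2)c1`, gives 2.27. The change a number 0.55 log units lower from compound 1 to compound 2 (beyond the scatter) shows what a ring with 2 hetero atoms in place of one with 1 does alone. Compound 3, `CCc1cnc(-c2cc(Oc3ccc(S(C)(=O)=O)cc3)cc(OC(C)C)c2)[nH]c1=O`, carries a group of 9 heavy atoms (6 carbon, 2 nitrogen, 1 oxygen; one six-membered aromatic ring with 2 hetero atoms) in place of a group of 7 heavy atoms (5 carbon, 1 nitrogen, 1 oxygen; one six-membered aromatic ring with 1 hetero atom), on an aromatic carbon, so the entering group also brings more carbon. That extra carbon is expected to offset the drop seen in compound 2, giving a number 0.28 log units higher from compound 1 to compound 3 (within the scatter). Compound 3 is therefore estimated at 3.1, between 2.6 and 3.6.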

Compound 3, distribution coefficient: 3.11
For compound 3 the middle estimate is 0.01 log units below the measured one; measured number inside the range.
By their numbers in this assay, from the lowest: compound 2; then compounds 1 and 3 (each within the scatter of the next).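

With the ring of 2 hetero atoms kept, the group of 9 heavy atoms, with 6 carbon against 4, gives a number 0.84 log units higher from compound 2 to compound 3 (beyond the scatter) in this assay, so the two groups at this position are clearly told apart. Set against the group that left, the same entering group gives a number 0.29 log units higher from compound 1 to compound 3 (within the scatter), so the two compounds cannot be told apart in this read-out. Nothing available accounts for either step. The compounds shown leave open whether a longer chain such as propyl on the same ring would go on raising the number, and where an amine or a carboxylic acid there would fall.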